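Carboxy to hydroxymethyl in a series without measured inhibition

The source may report more compounds than this note shows. Statements on the series, on what has been measured and on what is new or still open speak of the compounds shown alone.

Measured compounds:
compound 1 `COc1ccc2c(c1)cc(C(=O)NCc1ccccc1)n2C` — > 100000 nM
compound 2 `Cn1c(C(=O)O)cc2cc(OCCCC3CCN(Cc4ccccc4)CC3)ccc21` — > 100000 nM

In an assay on isolated protein for inhibition of Amine oxidase [flavin-containing] A (Homo sapiens), read by fluorescence, with stated times of 30 min and 1 h (a lower number here means a stronger inhibitor, a higher number a weaker inhibitor), compound 1 reaches only the assay limit, > 100000 nM. In this assay compound 2 likewise gives only a limit, > 100000 nM. Compound 2 therefore stands at the limit, as stated in the limit of > 100000 nM in this assay, at which 2 of the 2 values shown sit, with no number of its own to compare against; both values shown are limits.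

Compound 3 `Cn1c(CO)cc2cc(OCCCC3CCN(Cc4ccccc4)CC3)ccc21` has not yet been measured. It differs from compound 2 by hydroxymethyl in place of carboxy on an aromatic carbon. No measured step exists for this kind of change here, so no direction beyond the scatter can be read from the series; only that both shown compounds sit at the limit.

Compound 3 is expected to remain weak in this assay, estimated at 90000 nM with a range from 20000 nM to 400000 nM. The step from compound 2 to compound 3 that this estimate implies, an at least 1.1-fold lower number from compound 2 to compound 3 (0.04 log units; that floor lies within the scatter), is an expectation only and most likely the result is again a limit.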

Compound 3, half-maximal inhibitory concentration: 4260 nM
Beside the measured number, compound 3's estimate is 21-fold (1.32 log units) above it; measured number outside the range, below it.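

In this assay, hydroxymethyl in place of carboxy gives an at least 23-fold lower number from compound 2 to compound 3 (1.37 log units; beyond the scatter), the only change shown that brings a compound off the assay limit. This position, on an aromatic carbon of the five-membered aromatic ring with 1 nitrogen, therefore responds to the group it carries, although each group has 1 hydrogen-bond donor, 1 hydrogen-bond acceptor and no net charge. The step is a floor rather than a full size, with a number at only one end: the limit of > 100000 nM in this assay, at which 2 of the 3 values shown sit.

On these data alone, it remains open whether the shift comes from the hydroxymethyl itself or from the loss of the carboxy, and whether an amine, a methyl ester or a longer chain ending in hydroxyl would hold it. No pair shown tests the rest of compound 3 on its own, so the contribution of those parts stays unread.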